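Exchanging the Amine Substituent of Compound 3

A few compounds are considered here, and "the series" means these few. Any claim that something is new, unique, unknown or untested is made for them only; others in the source may bear on it.

compound 1, `CN1CCN(c2ccc(Nc3ncc4c(n3)N(C3CCCC3)CC(=O)N4)cc2)CC1`: 21300 nM
compound 2, `CC1CCN(c2ccc(Nc3ncc4c(n3)N(C3CCCC3)CC(=O)N4)cc2)CC1`: > 30000 nM
compound 3, `CN1CCN(c2ccc(Nc3ncc4c(n3)N(C3CCCC3)CC(=O)N4)nc2)CC1`: > 30000 nM

Of the compounds shown here, three built on one shared core have been tested in a functional assay on HeLa cells (Homo sapiens) for inhibition, read by MTT assay, with a stated time of 48 h; a lower number here means a stronger inhibitor, a higher number a weaker inhibitor. Compound 1 gives 21300 nM in this assay. For compound 2 the value > 30000 nM is a limit of this assay rather than a number. For compound 3 the value > 30000 nM is likewise a limit of this assay and not a number. Compound 3 thus stands at the limit of > 30000 nM in this assay, at which 2 of the 3 values shown sit, and its true potency is not resolved. Within the data shown here, the one change between measured compounds is an at least 1.4-fold higher number from compound 1 to compound 2 (0.14 log units; that floor lies within the scatter), and it is the only step from which anything can be read.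

Compound 4, `O=C1CN(C2CCCC2)c2nc(Nc3ccc(N4CCCCC4)cn3)ncc2N1`, differs from compound 3 by piperidin-1-yl in place of 4-methylpiperazin-1-yl on an aromatic carbon. The closest measured step is the change from compound 1 to compound 2, and its size is not resolved beyond the scatter. Compound 3 itself is known only as a limit. A related exchange on compound 3 is therefore expected to leave the number at or beyond that limit, and the step that the limit leaves unreadable from compound 3 to compound 4 is expected to be small or undetectable. Compound 4 is estimated at 40000 nM in this assay, within 15000 nM to 100000 nM, and most probably reported again as a limit.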

Compound 4, half-maximal inhibitory concentration: > 30000 nM
Compound 4: a limit, no number (the forecaster's own chance of this, stated with the estimate: 75%); the middle value does not contradict the limit.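

Compound 3 and compound 4 both give only a limit in this assay, not a number, so no step between them can be read: the limit of > 30000 nM in this assay, at which 3 of the 4 values shown sit.

The compounds shown leave open what the true potency of either compound is, and whether piperidin-1-yl in place of 4-methylpiperazin-1-yl changes it at all.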